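Notes on the series: from compound 2 to compound 4

This account rests on a few compounds, and the source may have more. Where it says the series, first, only, none or still open, it means among the compounds named here.

Of the compounds shown here, three of the shared core have been measured. Compound 1 `O=S1(=O)CCC(CNCCCCN(C[C@H]2Cc3ccccc3CN2)[C@H]2CCCc3cccnc32)CC1` gives 17 nM in a functional assay on cells for antagonist activity at C-X-C chemokine receptor type 4 (Homo sapiens), read by fluorescence and calcium flux, with stated times of 25 min and 90 s; a higher number here means a weaker inhibitor, a lower number a stronger inhibitor. Compound 2 `c1ccc2c(c1)CN[C@@H](CN(CCCCNC1CCCCC1)[C@H]1CCCc3cccnc31)C2` gives 75.2 nM, and compound 3 `O=S1(=O)CCC(NCCCCN(C[C@H]2Cc3ccccc3CN2)[C@H]2CCCc3cccnc32)CC1` gives 45.5 nM. Compound 2 holds the highest number of the three; its step to compound 3 is within the scatter, while the step from compound 1 is beyond it, a 4.4-fold higher number from compound 1 to compound 2 (0.65 log units; beyond the scatter). The two steps that vary the group on the amine nitrogen, a 4.4-fold higher number from compound 1 to compound 2 (0.65 log units; beyond the scatter) and a 1.7-fold lower number from compound 2 to compound 3 (0.22 log units; within the scatter), were modest at most.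

Compound 4 `C(=C/CN(C[C@H]1Cc2ccccc2CN1)[C@H]1CCCc2cccnc21)\CNCc1cccnc1` differs from compound 2 in this way: a group of 11 heavy atoms (9 carbon, 2 nitrogen; one six-membered aromatic ring with 1 hetero atom) in place of a group of 10 heavy atoms (9 carbon, 1 nitrogen; one six-membered non-aromatic ring of carbon only), on a saturated chain carbon bound to an amine nitrogen. Within the data shown here, no measured step exchanges a saturated carbocycle for an aromatic ring and adds a double bond in the chain at once, so the bearing of the prior steps is indirect; they suggest that changes in this region move the number modestly. The estimate for compound 4 is therefore close to compound 2, a step of a 1.7-fold lower number from compound 2 to compound 4 (0.22 log units; within the scatter), expected at 45 nM with a range from 12 nM to 180 nM.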

Compound 4, half-maximal inhibitory concentration: 92.8 nM
Compound 4: the middle estimate sits 2.1-fold (0.31 log units) below what was measured; the range from low to high includes it.
By their numbers in this assay, from the lowest: compound 1; then compounds 3, 2 and 4 (each within the scatter of the next, the first and the last beyond it).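

In this assay, replacing 3-(cyclohexylamino)propyl with a group carrying a six-membered aromatic ring with 1 hetero atom and 1 double bond outside aromatic rings gives a 1.2-fold higher number from compound 2 to compound 4 (0.09 log units; within the scatter). The earlier steps shown here changed only the group on the amine nitrogen, whereas this one shows that ring type and chain can change together at this place without a step beyond the scatter, so for compound 4 the carbocycle of compound 2 is not needed to stay within the scatter. No measured information bears on why the two values stay this close.

On these data alone, since both changes arrive in one step, it remains open whether each alone leaves the number in place or whether their contributions cancel. A phenyl ring on the same unsaturated chain, or a cyclohexyl group on it, would separate the two.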